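From isopropyl to methyl on compound 2

The compounds below may be only part of what the source reports. "The series", "measured", "known", "first", "only" and "open" are said of these compounds alone.

Compound 1 `O=C(NCCCCCCSSCCCCCCNC(=O)c1cc(-c2ccncc2)n[nH]1)c1cc(-c2ccncc2)n[nH]1` gives 7150 nM
Compound 2 `CC(C)C(=O)SCCCCCCNC(=O)c1cc(-c2ccncc2)n[nH]1` gives 15200 nM
Compound 3 `O=C(CCCCCCS)Nc1ccccc1` gives > 50000 nM as a limit

Going by the values given here, all three results come from a functional assay on MCF7 cells (Homo sapiens) for inhibition, read by MTT assay, with a stated time of 96 h (a lower number here means a stronger inhibitor of growth, a higher number a weaker inhibitor of growth), and the one for compound 3 is a limit, not a number. Of the two true numbers, compound 2 has the higher, and its gap to compound 1 lies beyond the scatter.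

Compound 4 `CC(=O)SCCCCCCNC(=O)c1cc(-c2ccncc2)n[nH]1` is not yet measured and carries methyl in place of isopropyl on a carbonyl carbon. Among the compounds with values here, no measured pair shows this kind of change, so the starting point is compound 2 at 15200 nM and no shift beyond the scatter is expected in this assay for this small swap. The estimated size of the change a 1.2-fold lower number from compound 2 to compound 4 (0.07 log units; within the scatter) is correspondingly small. Compound 4 is estimated at 13000 nM with an expected range from 6000 nM to 30000 nM for now.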

Compound 4, concentration for 50% growth inhibition: 24900 nM
The estimate for compound 4 lay 1.9-fold (0.28 log units) below the measured number; low and high end bracket the measured number.
By their numbers in this assay, from the lowest: compound 1; then compounds 2 and 4 (each within the scatter of the next). At a limit, above all of these: compound 3.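

In this assay, methyl in place of isopropyl on a carbonyl carbon gives the first single-place comparison, and a 1.6-fold higher number from compound 2 to compound 4 (0.21 log units; within the scatter) shows that this swap changes the number by no more than repeat measurements would. Compound 4 still gives a true number, whereas compound 3 alone stands at a limit, which is not a number: the limit of > 50000 nM in this assay, at which 1 of the 4 values shown sits.

Going by these compounds, whether a longer chain or an amine on this carbonyl carbon would move the number beyond the scatter remains open.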